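This account rests on a few compounds, and the source may have more. Where it says the series, first, only, none or still open, it means among the compounds named here.

Measured in a functional assay on MCF7 cells (Homo sapiens) for antiproliferative activity, read by MTT assay, with a stated time of 72 h; on this read-out lower numbers stand for stronger inhibition and higher numbers for weaker inhibition:
Compound 1 `COc1ccc(N2C(=O)COc3ccc(-c4cnc(Cl)c(NS(=O)(=O)c5ccc(F)cc5)c4)cc32)cc1`: 36000 nM
Compound 2 `COc1ccc(N2C(=O)COc3ccc(-c4cnc5ccccc5c4)cc32)cc1`: > 40000 nM (a limit of the assay, not a number)
Compound 3 `COc1ccc(N2C(=O)COc3ccc(-c4cnc(OC)c(NS(=O)(=O)c5ccc(F)cc5)c4)cc32)cc1`: 8260 nM

Only two of these three results are actual numbers, and compound 1 has the higher one at 36000 nM. Its nearest neighbour lies one measured step away: a 4.4-fold lower number from compound 1 to compound 3 (0.64 log units; beyond the scatter). The remaining result is the limit of > 40000 nM in this assay, at which 1 of the 3 values shown sits, so the upper end of the scale is close to the numbers that concern this account.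

Compound 4 `O=C1COc2ccc(-c3cnc(Cl)c(NS(=O)(=O)c4ccc(F)cc4)c3)cc2N1C1CC1` keeps the core of compound 1 and changes a single group: cyclopropyl in place of 4-methoxyphenyl on an amide-type nitrogen in a ring. Cyclopropyl stands in place of 4-methoxyphenyl on an amide-type nitrogen in a ring.

For the measured compounds named here, the one measured step does not touch that place. It is methoxy in place of chloro on an aromatic carbon, and it gives only a rough idea of how far one change can move a number in this series: a 4.4-fold lower number from compound 1 to compound 3 (0.64 log units; beyond the scatter). No measurement shows what a change on the amide-type nitrogen does, so no direction can be expected, and the best guess is no step beyond the scatter in this assay. The estimated step is a 1.2-fold lower number from compound 1 to compound 4 (0.08 log units; within the scatter). Compound 4 is expected at 30000 nM, with an estimated range from 10000 nM to 40000 nM.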

Compound 4, half-maximal inhibitory concentration: 16700 nM
Estimate against measurement, compound 4: 1.8-fold (0.25 log units) above, within the range that was stated.
By their numbers in this assay, from the lowest: compound 3; then compound 4; then compound 1. At a limit, above all of these: compound 2.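

Setting cyclopropyl in place of 4-methoxyphenyl on the amide-type nitrogen in a ring gives a 2.2-fold lower number from compound 1 to compound 4 (0.33 log units; beyond the scatter) in this assay, so this place, which the earlier step did not touch, also moves the number. The 4-methoxyphenyl group, with its six-membered aromatic ring of carbon only and its 8 heavy atoms, is therefore not required for the activity of compound 1 in this assay, since a group of 3 heavy atoms with no hydrogen-bond acceptor does not raise the number. Even so, this change leaves compound 4 in the upper part of the scale, and the end of that scale is marked by compound 2, whose result is a limit and not a number: the limit of > 40000 nM in this assay, at which 1 of the 4 values shown sits.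

This single pair cannot separate the loss of the methoxy group from the loss of the aromatic ring, and it leaves open what a plain phenyl, a benzyl group or a longer chain such as butyl would do on that nitrogen. Also open, as far as these compounds go, is whether methoxy in place of chloro on the aromatic carbon would lower the number further on a compound that carries cyclopropyl.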